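The compounds below may be only part of what the source reports. "The series", "measured", "known", "first", "only" and "open" are said of these compounds alone.

Working notes on the series

Three compounds carry numbers in a functional assay on JeKo-1 cells (Homo sapiens) for inhibition, read by luminescence and CellTiter-Glo, with a stated time of 72 h; on this read-out lower numbers stand for stronger inhibition and higher numbers for weaker inhibition. Compound 2 `O=C(CCl)Nc1ccc(Cn2nc(-c3ccc(Oc4ccccc4)cc3)cc2C(=O)O)cc1` gives 2500 nM in this assay. Compound 3 `O=C(CCl)Nc1cccc(Cn2nc(-c3ccc(Oc4ccccc4)cc3)cc2C(=O)O)c1` gives 6300 nM, and compound 1 `C=CC(=O)Nc1cccc(Cn2nc(-c3ccc(Oc4ccccc4)cc3)cc2C(=O)OCC)c1` gives 7600 nM. Within this set compound 3 stands second highest of the three numbers: its gap to compound 1 lies within the scatter, while the step of a 2.5-fold higher number from compound 2 to compound 3 (0.40 log units; beyond the scatter) is beyond it.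

Compound 4 `C=CC(=O)Nc1cccc(Cn2nc(-c3ccc(Oc4ccccc4)cc3)cc2C(=O)O)c1` is not yet measured. It differs from compound 3 by vinyl in place of chloromethyl on a carbonyl carbon. Among the measured compounds shown here, no measured pair shows this exact exchange on an otherwise identical scaffold: compound 1 carries the vinylcarbonyl group but differs from compound 4 in more than one place, and its value sits close to that of compound 3. For the measured compounds named here, the one measured step, from compound 2 to compound 3, concerns a different position and does not speak to the carbonyl substituent. Going by the values given here, with no step bearing directly on this change, the expectation for this assay is a step of no change at the digits printed from compound 3 to compound 4 (within the scatter) from compound 3 to compound 4, none beyond the scatter. Compound 4 is therefore estimated at 6300 nM, with a range from 2500 nM to 16000 nM.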

Compound 4, half-maximal inhibitory concentration: > 60000 nM
Compound 4: a limit, no number; the forecaster's own chance of this, stated with the estimate: 5%; at least 9.5-fold (0.97 log units) between middle value and limit.
By their numbers in this assay, from the lowest: compound 2; then compounds 3 and 1 (each within the scatter of the next). At a limit, above all of these: compound 4.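

Compound 4 reads as a limit of the assay, not a number: the limit of > 60000 nM in this assay, at which 1 of the 4 values shown sits.

With the rest of compound 3 unchanged, vinyl in place of chloromethyl on a carbonyl carbon gives an at least 9.5-fold higher number from compound 3 to compound 4 (0.97 log units; beyond the scatter), the first sign in this assay that this substituent matters. With the vinylcarbonyl group kept, hydrogen in place of ethyl on an oxygen next to a carbonyl group gives an at least 7.8-fold higher number from compound 1 to compound 4 (0.89 log units; beyond the scatter), and 3-((vinylcarbonyl)amino)phenyl in place of 4-(((chloromethyl)carbonyl)amino)phenyl gives an at least 24-fold higher number from compound 2 to compound 4 (1.38 log units; beyond the scatter), so the loss appears in all three comparisons.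

The limit leaves the true size of these steps open. Also open, as far as these compounds go, is how a 4-((vinylcarbonyl)amino)phenyl group would read on the shared core, or a bromomethyl group or longer chain on the same carbonyl carbon.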